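Isopropyl for Phenoxy on a Second Pyrazole Core

The source may hold more compounds than are shown below. What is called first, only, known or untested is meant among the compounds shown, and "the series" means these compounds.

Measured compounds:
compound 1, `CC(C)Oc1ccc(-c2cc(C(=O)O)nn2-c2ccc(Oc3ccccc3)cc2)cc1`, 712 nM
compound 2, `CC(C)Oc1ccc(-c2cc(C(=O)O)nn2-c2ccc(C(C)C)cc2)cc1`, 2140 nM
compound 3, `CC(C)Oc1ccc(C(=O)Nc2c(C(=O)O)nn(-c3ccc(Oc4ccccc4)cc3)c2-c2ccc(OCc3ccccc3)cc2)cc1`, 4470 nM

In an assay for displacement of a labelled ligand from E3 ubiquitin-protein ligase Mdm2 (Homo sapiens), read by fluorescence polarization, with a stated time of 30 min (a higher number here means a weaker inhibitor, a lower number a stronger inhibitor), compound 1 gives 712 nM, and compound 2, which carries the same change that is now in question, gives 2140 nM. The change between them is isopropyl in place of phenoxy on an aromatic carbon, and it made a step of a 3.0-fold higher number from compound 1 to compound 2 (0.48 log units; beyond the scatter). Compound 3 sits on a different core; its difference from compound 1 is not broken down here. In this assay compound 3 gives 4470 nM, the highest of the three numbers.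

Compound 4, `CC(C)Oc1ccc(C(=O)Nc2c(C(=O)O)nn(-c3ccc(C(C)C)cc3)c2-c2ccc(OCc3ccccc3)cc2)cc1`, is not yet measured. It differs from compound 3 by isopropyl in place of phenoxy on an aromatic carbon, and the place lines of the two changes read the same word for word, so this is the same change that took compound 1 to compound 2. It occurs twice among these compounds, and only the first occurrence is measured.

The expectation rests on one pair alone. Among the compounds with values here, on the core of compound 1 the change weakened binding by a 3.0-fold higher number from compound 1 to compound 2 (0.48 log units; beyond the scatter), and there is no measured pair on the core of compound 3 to say whether that core responds in the same way. The step from compound 3 to compound 4 is therefore estimated at a 2.7-fold higher number from compound 3 to compound 4 (0.43 log units; beyond the scatter), on the assumption that the two cores behave alike, with a wide range to cover the chance that they do not. Compound 4 is expected to give 12000 nM in this assay, most likely between 5000 nM and 30000 nM.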

Compound 4, inhibition constant: 2190 nM
Beside the measured number, compound 4's estimate is 5.5-fold (0.74 log units) above it, and the stated range ends above it.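

In this assay, isopropyl in place of phenoxy on an aromatic carbon gives a 2.0-fold lower number from compound 3 to compound 4 (0.31 log units; beyond the scatter), so on the core of compound 3 the change goes with a stronger inhibitor, whereas on the core of compound 1 it went with a weaker one. The change therefore cannot be carried from one core to the other in this series with its direction kept, and the two steps differ by more than repeated measurement would explain: the same change on two cores in this assay, a 3.0-fold higher number (0.48 log units; beyond the scatter) from compound 1 to compound 2 and a 2.0-fold lower number (0.31 log units; beyond the scatter) from compound 3 to compound 4, 6.1-fold (0.79 log units) apart, beyond the scatter of two such steps This does not show what causes the reversal, since each core offers a single pair, the two cores differ in more than one place, and neither step says anything about other pairs on the same cores.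

The compounds shown leave open which of the differences between the two cores decides the direction of the step, and whether that direction would hold on a third core. They also leave open whether other groups in the same place, such as a methyl group, a cyclohexyl ring or an amine, would follow the isopropyl result on each core or depart from it.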